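Removing the Chloro Group from the Benzoyl Amide

A few compounds are considered here, and "the series" means these few. Any claim that something is new, unique, unknown or untested is made for them only; others in the source may bear on it.

Measured compounds:
Compound 1, `O=C(Nc1ccccc1O)C1CCc2ccccc2N1C(=O)c1ccccc1Cl`: 46900 nM
Compound 2, `O=C(Nc1ccccc1O)c1ccc2ccccc2n1`: 87500 nM

Of the compounds shown here, two have been tested in a functional assay on NCI-H23 cells (Homo sapiens) for cytotoxicity, read by sulforhodamine B assay, with a stated time of 72 h; on this read-out higher numbers stand for weaker inhibition of growth and lower numbers for stronger inhibition of growth. Compound 1 gives 46900 nM and compound 2 gives 87500 nM; compound 1 stands at the smaller of these two numbers, but the gap between them lies within the usual scatter, so neither compound can be called the more active. Both inhibit growth only weakly.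

Compound 3, `O=C(Nc1ccccc1O)C1CCc2ccccc2N1C(=O)c1ccccc1`, has not yet been measured. It differs from compound 1 in one place: hydrogen in place of chloro on an aromatic carbon. Going by the values given here, no measured pair shows this change, so nothing in the data tells how it acts in this assay. The expected step is a 1.3-fold higher number from compound 1 to compound 3 (0.11 log units; within the scatter), most likely nothing beyond the scatter. Compound 3 is therefore estimated at 60000 nM, within a range from 20000 nM to 180000 nM.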

Compound 3, concentration for 50% growth inhibition: 3490 nM
For compound 3 the middle estimate is 17-fold (1.24 log units) above the measured one, and the stated range ends above it.
By their numbers in this assay, from the lowest: compound 3; then compounds 1 and 2 (each within the scatter of the next).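

In this assay, going by these compounds alone, exchanging 2-chlorophenyl for phenyl gives a 13-fold lower number from compound 1 to compound 3 (1.13 log units; beyond the scatter) and this is the first step here between compounds that differ in one place. It shows that this single aromatic carbon, which carries a chloro in compound 1 and a hydrogen in compound 3, has a strong bearing on growth inhibition, and that on this core the compound without the chloro is clearly the stronger inhibitor. Nothing measured here explains why this exchange has so large an effect.

Still open, going by these compounds, is how other groups would behave on this same aromatic carbon, such as a fluoro, a methyl or a methoxy group in place of the hydrogen of compound 3. A single pair also cannot tell whether the same exchange would act alike on another core.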